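Diaminoquinoxaline series: aryl variation at the benzylic amine

The source may hold more compounds than are shown below. What is called first, only, known or untested is meant among the compounds shown, and "the series" means these compounds.

Measured so far:
compound 1 `Nc1cc(N)c2nc(-c3ccccc3)c(Oc3ccc(Cl)c(Cl)c3)nc2c1` — < 100000 nM
compound 2 `CCOC(=O)[C@H](CCC(=O)O)NC(=O)c1ccc(CNc2nc3cc(N)cc(N)c3nc2-c2ccccc2)cc1` — < 100000 nM
compound 3 `Nc1cc(N)c2nc(-c3ccccc3)c(NCc3ccc(Cl)c(Cl)c3)nc2c1` — < 100000 nM

Notes on the series. In a functional assay on OVCAR-4 cells (Homo sapiens) for inhibition, read by sulforhodamine B assay, with a stated time of 48 h (a higher number here means that more compound is tolerated, a lower number that less compound is tolerated), compound 1 gives < 100000 nM, which is a limit of the assay and not a number. In this assay compound 2 gives < 100000 nM, again a limit. In this assay compound 3 gives < 100000 nM, also a limit. Where compound 3 stands can therefore be said only through (the limit of < 100000 nM in this assay, at which 3 of the 3 values shown sit); no measured step exists between any two of these compounds, and nothing separates compound 3 from compound 1 or compound 2 on the numbers shown.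

Compound 4 `COc1ccc(CNc2nc3cc(N)cc(N)c3nc2-c2ccccc2)cc1OC` differs from compound 3 in one place: 3,4-dimethoxyphenyl in place of 3,4-dichlorophenyl on a saturated chain carbon bound to a nitrogen on an aromatic ring. Going by the values given here, with no measured step, no size of step in this assay can be read from the data; the working expectation is a step from compound 3 to compound 4 that stays within the scatter, a step that the limit leaves unreadable from compound 3 to compound 4, and this is only an estimate. Compound 4 is expected to give about 20000 nM in this assay, with a range from 2000 nM to 100000 nM, and it may well again be reported only as a limit.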

Compound 4, concentration lethal to 50% of the cells: 52500 nM
Beside the measured number, compound 4's estimate is 2.6-fold (0.42 log units) below it, within the range that was stated.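

No step from compound 3 to compound 4 can be read in this assay, because the value of compound 3 is a limit and not a number: the limit of < 100000 nM in this assay, at which 3 of the 4 values shown sit.

The compounds shown leave open whether 3,4-dimethoxyphenyl in place of 3,4-dichlorophenyl changes the lethal concentration at all.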